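Pyrrolidin-1-yl for Diethylamino: A Small Expected Step

The source may report more compounds than this note shows. Statements on the series, on what has been measured and on what is new or still open speak of the compounds shown alone.

From a functional assay on PC-3 cells (Homo sapiens) for antiproliferative activity, read by MTT assay, with a stated time of 72 h (on this read-out lower numbers stand for stronger inhibition and higher numbers for weaker inhibition), come two values so far:
- Compound 1 `O=C(N/N=C/c1ccccc1)Nc1ccc(Oc2ccnc3[nH]ccc23)cc1` with 10200 nM
- Compound 2 `CCN(CC)CCCn1cccc1/C=N/NC(=O)Nc1ccc(Oc2ccnc3[nH]ccc23)c(F)c1` with 2950 nM

Compound 2 holds the lower number of the two, and the gap to compound 1 lies beyond the scatter. Compound 3 `O=C(N/N=C/c1cccn1CCCN1CCCC1)Nc1ccc(Oc2ccnc3[nH]ccc23)c(F)c1` puts pyrrolidin-1-yl in place of diethylamino, on a saturated chain carbon, three bonds along the chain from an aromatic nitrogen pyrrolidin-1-yl in place of diethylamino on a saturated chain carbon, three bonds along the chain from an aromatic nitrogen and changes nothing else. For the measured compounds named here, no measured pair shows this swap, so the expectation stays close to compound 2 at 2950 nM with no change beyond the scatter in this assay as the likely outcome. The expected size is a step of a 1.2-fold lower number from compound 2 to compound 3 (0.07 log units; within the scatter) at most slightly downward. For compound 3 the estimated value is 2500 nM with an expected range from 1200 nM to 5500 nM in this read-out.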

Compound 3, half-maximal inhibitory concentration: 3580 nM
For compound 3 the middle estimate is 1.4-fold (0.16 log units) below the measured one; the measured number falls inside the stated range.
By their numbers in this assay, from the lowest: compounds 2 and 3 (each within the scatter of the next); then compound 1.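

In this assay, pyrrolidin-1-yl in place of diethylamino gives a 1.2-fold higher number from compound 2 to compound 3 (0.08 log units; within the scatter) on this chain, so the read-out does not separate the two groups. The end of the 3-(diethylamino)propyl chain can therefore carry a ring amine as well as an open one, which compound 2 alone could not show. No measurement here addresses why the two groups read alike. From the compounds shown here alone, whether a piperidine, a morpholine or a carboxylic acid at this chain end, or a longer chain, would also read alike stays open. This single pair also leaves open whether the swap behaves the same way on a different core.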